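The source may report more compounds than this note shows. Statements on the series, on what has been measured and on what is new or still open speak of the compounds shown alone.

Three compounds with a shared core have been compared in an assay on cells for displacement of a labelled ligand from Glucagon receptor (Homo sapiens), in the presence of a further agent that is not named here; on this read-out lower numbers stand for stronger inhibition and higher numbers for weaker inhibition. Compound 1 `CCCC(Oc1ccc(-n2cc(C(=O)N(C)C)cn2)cc1)c1ccc(C(=O)NCCC(=O)O)cc1` gives 6500 nM, compound 2 `CCCC(Oc1ccc(-n2cccn2)cc1)c1ccc(C(=O)NCCC(=O)O)cc1` gives 4100 nM, and compound 3 `CCCC(Oc1ccc(-n2cc(C(F)(F)F)cn2)cc1)c1ccc(C(=O)NCCC(=O)O)cc1` gives 890 nM, the lowest number of the three. The measured steps are a 1.6-fold lower number from compound 1 to compound 2 (0.20 log units; within the scatter), a 7.3-fold lower number from compound 1 to compound 3 (0.86 log units; beyond the scatter) and a 4.6-fold lower number from compound 2 to compound 3 (0.66 log units; beyond the scatter). Compound 4 `CCCC(Oc1ccc(-n2cc3c(n2)CCCC3)cc1)c1ccc(C(=O)NCCC(=O)O)cc1` differs from compound 3 in one place: a group of 9 heavy atoms (7 carbon, 2 nitrogen; one five-membered aromatic ring with 2 hetero atoms, one six-membered non-aromatic ring of carbon only) in place of a group of 9 heavy atoms (4 carbon, 2 nitrogen, 3 fluorine; one five-membered aromatic ring with 2 hetero atoms), on an aromatic carbon. Among the measured compounds shown here, both steps leading to compound 3 bear on this change, each modest, yet neither exchanges the whole trifluoromethyl-bearing group, so the new ring system has no direct precedent here. A small loss or no change beyond the scatter is therefore expected in this assay, as the step of a 1.7-fold higher number from compound 3 to compound 4 (0.23 log units; within the scatter). Compound 4 is accordingly estimated at 1500 nM, within 500 nM to 4500 nM.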

Compound 4, inhibition constant: 690 nM
Estimate against measurement, compound 4: 2.2-fold (0.34 log units) above; measured number inside the range.
By their numbers in this assay, from the lowest: compounds 4 and 3 (each within the scatter of the next); then compounds 2 and 1 (each within the scatter of the next).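

At this place on the six-membered aromatic ring, the group carrying a six-membered non-aromatic ring of carbon only stands level with 4-(trifluoromethyl)-1H-pyrazol-1-yl in this assay, with a 1.3-fold lower number from compound 3 to compound 4 (0.11 log units; within the scatter). Trifluoromethyl is therefore not the only substituent that separates a compound from the unsubstituted and dimethylcarbamoyl analogues, as shown by a 5.9-fold lower number from compound 2 to compound 4 (0.77 log units; beyond the scatter) and a 9.4-fold lower number from compound 1 to compound 4 (0.97 log units; beyond the scatter). No supporting data explain this result. The compounds shown leave open whether a nitrile, a methyl group or a chlorine atom on the five-membered aromatic ring would give a similar number.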